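Ethoxy in Place of 2-Carboxypyrrolidin-1-yl on a Carbonyl Carbon

The compounds below may be only part of what the source reports. "The series", "measured", "known", "first", "only" and "open" are said of these compounds alone.

Compound 1 (`O=C(O)[C@@H]1CCCN1C(=O)/C=C/c1ccncc1-c1ccc2ccccc2c1`) offers no starting number. In a functional assay on HCT-116 cells (Homo sapiens) for inhibition, read by MTT assay, with a stated time of 72 h (on this read-out lower numbers stand for stronger inhibition of growth and higher numbers for weaker inhibition of growth), compound 1 is recorded as "not determined" (no result reported), so its standing can't be placed against the other compounds. Two related compounds do have results, though both have a core that differs from that of compound 1. Compound 2 (`CNC(=O)/C=C/c1ccncc1-c1ccc2cc[nH]c2c1`) gives 10400 nM in this assay, and compound 3 (`CCOC(=O)/C=C/c1ccncc1-c1ccc2[nH]ccc2c1`) gives 4830 nM.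

The next compound, compound 4 (`CCOC(=O)/C=C/c1ccncc1-c1ccc2ccccc2c1`), keeps the core of compound 1 and changes one group: ethoxy in place of 2-carboxypyrrolidin-1-yl on a carbonyl carbon. Within the data shown here, with no number for compound 1 and no measured step of this kind, the size of the change in this assay can't be read from the data, and no direction can be firmly assigned to it. Among the measured compounds shown here, the expectation is only that compound 4 will return a measurable value of the same order as those of the two related compounds. The closest guide is compound 3, which also carries ethoxy on a carbonyl carbon and gives 4830 nM. The estimate for compound 4 is 3500 nM, with an expected range from 900 nM to 12000 nM.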

Compound 4, concentration for 50% growth inhibition: 910 nM
Estimate against measurement, compound 4: 3.8-fold (0.59 log units) above; low and high end bracket the measured number.
By their numbers in this assay, from the lowest: compound 4; then compound 3; then compound 2.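

No new step can be read from compound 4, as compound 1 has no number in this assay to set against it. The compounds shown leave open how ethoxy in place of 2-carboxypyrrolidin-1-yl on a carbonyl carbon shifts the result in this assay on the core of compound 1. Nothing at hand bears on this result.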